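Branching the Hydroxyalkyl Chain on a Shared Kinase Core

A few compounds are considered here, and "the series" means these few. Any claim that something is new, unique, unknown or untested is made for them only; others in the source may bear on it.

Three compounds sharing one core were tested in an assay on isolated protein for inhibition of protein kinase C epsilon type (Homo sapiens), read by coupled enzyme assay; a lower number here means a stronger inhibitor, a higher number a weaker inhibitor. Compound 1 `N#CC1(c2cc(CCO)cc(-c3ccnc4[nH]nc(C(F)(F)F)c34)c2)CC1` gives 25 nM. Compound 2 `C[C@@H](O)Cc1cc(-c2ccnc3[nH]nc(C(F)(F)F)c23)cc(C2(C#N)CC2)c1`, which carries a methyl on the hydroxyl-bearing chain carbon, gives 34 nM in this assay. Compound 3 `CCC(O)Cc1cc(-c2ccnc3[nH]nc(C(F)(F)F)c23)cc(C2(C#N)CC2)c1`, with an ethyl at the same position, gives 49 nM in this assay. Compound 3 is separated from compound 2 by a 1.4-fold higher number from compound 2 to compound 3 (0.16 log units; within the scatter) and from compound 1 by a 2.0-fold higher number from compound 1 to compound 3 (0.29 log units; within the scatter), and compound 1 and compound 2 differ by a 1.4-fold higher number from compound 1 to compound 2 (0.13 log units; within the scatter), so the three numbers stand together within the scatter.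

Compound 4 `CC(C)C(O)Cc1cc(-c2ccnc3[nH]nc(C(F)(F)F)c23)cc(C2(C#N)CC2)c1` has not been measured. It differs from compound 3 by methyl in place of hydrogen on a saturated chain carbon bound to two saturated chain carbons. The three measured steps, each enlarging the chain at or next along from the same hydroxyl-bearing carbon, were all within the scatter, with only a slight drift toward higher numbers. On that basis compound 4 is expected to show a step of a 1.3-fold higher number from compound 3 to compound 4 (0.12 log units; within the scatter) in this assay, again within the scatter. The estimate for compound 4 is therefore 65 nM, with a range from 30 nM to 140 nM.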

Compound 4, inhibition constant: 215 nM
Compound 4: middle estimate off by 3.3-fold (0.52 log units), on the low side, and the stated range ends below it.
By their numbers in this assay, from the lowest: compounds 1, 2 and 3 (each within the scatter of the next); then compound 4.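

Among these compounds, at this position, a single added methyl can matter, which the earlier compounds gave no sign of: ethyl to isopropyl gives a 4.4-fold higher number from compound 3 to compound 4 (0.64 log units; beyond the scatter) in this assay. The larger chain changes also leave the scatter, with a 6.3-fold higher number from compound 2 to compound 4 (0.80 log units; beyond the scatter) and an 8.6-fold higher number from compound 1 to compound 4 (0.93 log units; beyond the scatter). Methyl in place of hydrogen therefore has no fixed size of effect in this series, and the step seen on the smaller chain does not carry over to the larger one: the same change on two cores in this assay, a 1.4-fold higher number (0.13 log units; within the scatter) from compound 1 to compound 2 and a 4.4-fold higher number (0.64 log units; beyond the scatter) from compound 3 to compound 4, 3.2-fold (0.51 log units) apart, beyond the scatter of two such steps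

The compounds shown leave open whether a longer unbranched chain, such as 2-hydroxypentyl, would stand with compound 3 or with compound 4, so branching and chain length cannot yet be told apart. They also leave open how an amine in place of the hydroxyl would read on the isopropyl-bearing chain.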